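Pyridin-2-yl for methoxyphenyl at an assay limit

This account rests on a few compounds, and the source may have more. Where it says the series, first, only, none or still open, it means among the compounds named here.

Compound 3 (`COc1cccc(N2CCN(Cn3nc(-c4ccc5c(c4)OCCO5)oc3=S)CC2)c1`) stands at the weak end of the three measured analogues. In a functional assay on BGC-823 cells (Homo sapiens) for antiproliferative activity, read by MTT assay, with a stated time of 48 h (a higher number here means a weaker inhibitor, a lower number a stronger inhibitor), compound 3 gives only a limit of the assay, > 50000 nM. Compound 2 (`Fc1ccc(N2CCN(Cn3nc(-c4ccc5c(c4)OCCO5)oc3=S)CC2)cc1`) likewise reaches only a limit in this assay, > 50000 nM. Compound 1 (`S=c1oc(-c2ccc3c(c2)OCCO3)nn1CN1CCN(c2cccc(Cl)c2Cl)CC1`) gives a number in this assay, 22600 nM. The two readable steps, an at least 2.2-fold higher number from compound 1 to compound 2 (0.34 log units; beyond the scatter) and an at least 2.2-fold higher number from compound 1 to compound 3 (0.34 log units; beyond the scatter), both move away from 2,3-dichlorophenyl and both end at the limit; the step that the two limits leave unreadable from compound 2 to compound 3 cannot be read, since (the limit of > 50000 nM in this assay, at which 2 of the 3 values shown sit). Compound 4 (`S=c1oc(-c2ccc3c(c2)OCCO3)nn1CN1CCN(c2ccccn2)CC1`) differs from compound 3 by pyridin-2-yl in place of 3-methoxyphenyl on an amine nitrogen in a ring. Among the compounds with values here, no measured step involves pyridin-2-yl, so the only guide is that every exchange of the group on the amine nitrogen in a ring so far has led to the limit. Compound 4 is therefore expected to sit near that limit as well, with an estimated this assay value of 50000 nM, ranging from 20000 nM to 150000 nM. The expected step is a number no higher from compound 3 to compound 4 (the limit leaves the size open).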

Compound 4, half-maximal inhibitory concentration: 25900 nM
The estimate for compound 4 lay 1.9-fold (0.29 log units) above the measured number, and the stated range covers the measured number.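

The group on the amine nitrogen in a ring does not have to be 2,3-dichlorophenyl for a number to appear in this assay: with pyridin-2-yl in its place the result is a 1.1-fold higher number from compound 1 to compound 4 (0.06 log units; within the scatter), so the two groups cannot be told apart here. This also shows that not every exchange at this position ends at the limit, as compound 2 and compound 3 do. The steps of an at least 1.9-fold lower number from compound 3 to compound 4 (0.28 log units; that floor lies within the scatter) and an at least 1.9-fold lower number from compound 2 to compound 4 (0.28 log units; that floor lies within the scatter) give only floors, and their true size stays hidden because they start from limits: the limit of > 50000 nM in this assay, at which 2 of the 4 values shown sit.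

From the compounds shown here alone, whether the place of the ring nitrogen counts remains open, and pyridin-3-yl or pyridin-4-yl would test that. So does the question of whether an unsubstituted phenyl would give a number or the limit.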